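Shortening the chain-end diene: compound 3 to compound 4

This account rests on a few compounds, and the source may have more. Where it says the series, first, only, none or still open, it means among the compounds named here.

Compound 1 `C/C=C/C=C/[C@](C)(O)C/C=C/[C@H]1[C@H](O)CC(=O)[C@@H]1CC/C=C\CCC(=O)OC`: 0.00003 mg/kg
Compound 2 `C/C=C\C=C\[C@](C)(O)C/C=C/[C@H]1[C@H](O)CC(=O)[C@@H]1CC/C=C\CCC(=O)OC`: 0.0000099 mg/kg
Compound 3 `COC(=O)CC/C=C\CC[C@H]1C(=O)C[C@@H](O)[C@@H]1/C=C/C[C@@](C)(O)/C=C/C(C)=C(C)C`: 0.00006 mg/kg

In a functional assay on the whole organism with Canis familiaris (Canis lupus familiaris) as the target (a lower number here means that less compound is needed, a higher number that more compound is needed for the effect), compound 3 stands highest of the three measured numbers; compound 1 is its nearest neighbour and compound 2 its furthest, with a 2.0-fold higher number from compound 1 to compound 3 (0.30 log units; within the scatter) and a 6.1-fold higher number from compound 2 to compound 3 (0.78 log units; beyond the scatter). Compound 4 `C=C/C(C)=C/[C@](C)(O)C/C=C/[C@H]1[C@H](O)CC(=O)[C@@H]1CC/C=C\CCC(=O)OC` is not yet measured and differs from compound 3 in one place: 2-methylbuta-1,3-dien-1-yl in place of 3,4-dimethylpenta-1,3-dien-1-yl on a saturated chain carbon bound to an oxygen on a saturated carbon and two saturated chain carbons. Both measured steps that bear on this chain end show the number rising when 1,2-dimethylprop-1-en-1-yl replaced prop-1-en-1-yl, one within the scatter and one modestly beyond it. Compound 4 removes part of that added carbon, so a small downward step is expected, a 1.5-fold lower number from compound 3 to compound 4 (0.18 log units; within the scatter), likely within the scatter. Compound 4 is therefore estimated at 0.00004 mg/kg, with a range from 0.00001 mg/kg to 0.00015 mg/kg.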

Compound 4, dose for half-maximal effect: 0.00071 mg/kg
Estimate against measurement, compound 4: 18-fold (1.25 log units) below; the measured number lies above the stated range.
By their numbers in this assay, from the lowest: compound 2; then compounds 1 and 3 (each within the scatter of the next); then compound 4.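

In this assay, among these compounds, this chain end proves far less forgiving than the earlier steps suggested: 2-methylbuta-1,3-dien-1-yl in place of 3,4-dimethylpenta-1,3-dien-1-yl gives a 12-fold higher number from compound 3 to compound 4 (1.07 log units; beyond the scatter). Replacing penta-1,3-dien-1-yl gives a 24-fold higher number from compound 1 to compound 4 (1.37 log units; beyond the scatter) and a 72-fold higher number from compound 2 to compound 4 (1.86 log units; beyond the scatter), so all three new steps are large, and these dienyl groups are not interchangeable here. Nothing known from these compounds explains the rise.

The compounds shown leave open whether the methyl group of 2-methylbuta-1,3-dien-1-yl matters. A plain buta-1,3-dien-1-yl group or a saturated butyl chain at this place would help to test this.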